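The compounds below may be only part of what the source reports. "The series", "measured", "known", "first", "only" and "open" are said of these compounds alone.

In an ADME assay on Caco-2 cells (Homo sapiens) for permeability, in the apical to basolateral direction (on this read-out lower numbers stand for lower permeability and higher numbers for higher permeability), the measured compounds are these:
Compound 1 `Cc1nc(-c2nc[nH]n2)ccc1-c1cnc2c(n1)N(CC1CCOCC1)C(=O)CN2` gives 9.7 10^-6 cm/s
Compound 2 `COCCN1C(=O)CNc2ncc(-c3ccc(-c4nc[nH]n4)nc3C)nc21` gives 5 10^-6 cm/s
Compound 3 `CO[C@H]1CC[C@H](N2C(=O)CNc3ncc(-c4ccc(-c5nc[nH]n5)nc4C)nc32)CC1` gives 9.7 10^-6 cm/s

Compound 3 stands level with compound 1 at the digits shown, and compound 2 lies within the scatter of both. Compound 4 `Cc1nc(-c2nc[nH]n2)ccc1-c1cnc2c(n1)N(CCC1CCOCC1)C(=O)CN2`, not yet measured, carries 2-(oxan-4-yl)ethyl in place of 4-methoxycyclohexyl on an amide-type nitrogen in a ring and keeps the shared core.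

Among the measured compounds shown here, three measured steps bear on this change, all among groups on that nitrogen. The closest is no change at the digits printed from compound 1 to compound 3 (within the scatter). Compound 1 carries (oxan-4-yl)methyl, the nearest match to the entering group. The steps of a 1.9-fold lower number from compound 1 to compound 2 (0.29 log units; within the scatter) and a 1.9-fold higher number from compound 2 to compound 3 (0.29 log units; within the scatter) also stay within the scatter. For the measured compounds named here, no measured compound carries the entering group itself, and three compounds are few. Even so, no step beyond the scatter is expected in this assay for this change. The expected step is a 1.1-fold lower number from compound 3 to compound 4 (0.03 log units; within the scatter) and would stay within the scatter. Compound 4 is expected at 9 10^-6 cm/s within an estimated range from 5 10^-6 cm/s to 16 10^-6 cm/s on these data.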

Compound 4, apparent permeability: 4.2 10^-6 cm/s
Compound 4: the middle estimate sits 2.1-fold (0.33 log units) above what was measured; measured number below the stated range.
By their numbers in this assay, from the lowest: compounds 4, 2, 1 and 3 (each within the scatter of the next, the first and the last beyond it).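

In this assay, the groups on the amide-type nitrogen of compounds 1, 2 and 3 all stayed within the scatter of one another, whereas 2-(oxan-4-yl)ethyl yields two modest steps beyond it: a 2.3-fold lower number from compound 3 to compound 4 (0.36 log units; beyond the scatter) and a 2.3-fold lower number from compound 1 to compound 4 (0.36 log units; beyond the scatter). So this position does respond to the group it carries: compound 4 has the same atoms as compound 3, joined differently, and lengthening (oxan-4-yl)methyl to 2-(oxan-4-yl)ethyl is enough to produce a step beyond the scatter. Compound 4 still cannot be told apart from compound 2, which carries 2-methoxyethyl: a 1.2-fold lower number from compound 2 to compound 4 (0.08 log units; within the scatter).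

Nothing available gives a cause for these steps. From the compounds shown here alone, whether a longer chain ending in oxan-4-yl would follow the same trend stays open, as does the effect of an amine at the end of the chain.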